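A few compounds are considered here, and "the series" means these few. Any claim that something is new, unique, unknown or untested is made for them only; others in the source may bear on it.

Measured so far in a functional assay (blood) for inhibition, with Homo sapiens as the target; a higher number here means a weaker inhibitor, a lower number a stronger inhibitor:

- compound 1, `COC1(c2csc(Sc3ccc4c(c3)OCC/C4=N\OCC#N)c2)CCOCC1`, 60 nM
- compound 2, `COC1(c2csc(Sc3ccc4c(c3)OCC/C4=N\O)c2)CCOCC1`, 40 nM
- compound 3, `CO[C@]1(c2cc(F)cc(S(=O)(=O)c3ccc(/C(C)=N/OCC#N)cc3)c2)CCO[C@@H](C)C1`, 60 nM

Compound 2 differs from compound 1 by hydrogen in place of cyanomethyl on an oxygen; that change made a 1.5-fold lower number from compound 1 to compound 2 (0.18 log units; within the scatter). Compound 4, `CO[C@]1(c2cc(F)cc(S(=O)(=O)c3ccc(/C(C)=N/O)cc3)c2)CCO[C@@H](C)C1`, has not yet been measured in this assay. It differs from compound 3 by hydrogen in place of cyanomethyl on an oxygen, which is the same change at the same place. How the core of compound 3 differs from the core of compound 1 is not broken down here. In this assay compound 3 reads level with compound 1 at the digits printed, and both stand within the scatter of compound 2.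

Compound 4 is expected to show a 1.5-fold lower number from compound 3 to compound 4 (0.18 log units; within the scatter) in this assay, because the same change gave a 1.5-fold lower number from compound 1 to compound 2 (0.18 log units; within the scatter). The estimate for compound 4 is 40 nM, within a range of 20 nM to 90 nM.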

Compound 4, half-maximal inhibitory concentration: 20 nM
For compound 4 the middle estimate is 2.0-fold (0.30 log units) above the measured one; the range from low to high includes it.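

In this assay, hydrogen in place of cyanomethyl on the oxygen gave a 3.0-fold lower number from compound 3 to compound 4 (0.48 log units; beyond the scatter), a modest step on the core of compound 3. Set beside the same change on the core of compound 1, the two steps cannot be told apart, so the change carried from one core to the other as far as these data can show: the same change on two cores in this assay, a 1.5-fold lower number (0.18 log units; within the scatter) from compound 1 to compound 2 and a 3.0-fold lower number (0.48 log units; beyond the scatter) from compound 3 to compound 4, 2.0-fold (0.30 log units) apart, within the scatter of two such steps Two cores do not show that it would carry to a third core in this series, and only the newer step lies beyond the scatter.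

The compounds shown leave open how other groups on that oxygen would read, such as methyl, a longer chain, or a chain ending in an amine or a carboxylic acid. They also leave open which of the differences between the two cores, if any, bears on the size of the step.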